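Benzylsulfanyl Variation in a Sulfonyl Guanidine Series

The compounds below may be only part of what the source reports. "The series", "measured", "known", "first", "only" and "open" are said of these compounds alone.

Compound 1 `Cc1cc(S(=O)(=O)/N=C(\N)n2nccc2-c2ccccc2)c(SCc2ccccc2C)cc1Cl`: 23000 nM
Compound 2 `Cc1cc(S(=O)(=O)/N=C(\N)n2nccc2-c2ccccc2)c(SCc2cccc3ccccc23)cc1Cl`: 58000 nM
Compound 3 `Cc1ccc(CSc2cc(Cl)c(C)cc2S(=O)(=O)/N=C(\N)n2nccc2-c2ccccc2)cc1`: 21000 nM

Three compounds sharing one core were measured in a functional assay on MCF7 cells (Homo sapiens) for cytotoxicity, read by MTT assay, with a stated time of 72 h; a higher number here means a weaker inhibitor, a lower number a stronger inhibitor. Compound 3 gives the lowest of the three numbers, though its nearest neighbour compound 1 sits within the scatter of it, as a 1.1-fold lower number from compound 1 to compound 3 (0.04 log units; within the scatter) shows; only compound 2 stands apart, with a 2.8-fold lower number from compound 2 to compound 3 (0.44 log units; beyond the scatter). The unmeasured compound 4 `Cc1cc(S(=O)(=O)/N=C(\N)n2nccc2-c2ccccc2)c(SCc2cccc(C(F)(F)F)c2)cc1Cl` differs from compound 3 in one place: 3-(trifluoromethyl)phenyl in place of 4-methylphenyl on a saturated chain carbon bound to a sulfur.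

Within the data shown here, two measured steps bear on this position. The exchange of 2-methylphenyl for 4-methylphenyl, a 1.1-fold lower number from compound 1 to compound 3 (0.04 log units; within the scatter), changed nothing beyond the scatter, while the larger swap to naphthalen-1-yl, a 2.5-fold higher number from compound 1 to compound 2 (0.40 log units; beyond the scatter), moved the number modestly upward. Among the measured compounds shown here, no measured step tests a trifluoromethyl group here, so the data give no direction for it. The account therefore expects the step of a 1.2-fold higher number from compound 3 to compound 4 (0.08 log units; within the scatter) to stay within the scatter. For compound 4 the estimate in this assay is 25000 nM, with a range from 10000 nM to 60000 nM.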

Compound 4, half-maximal inhibitory concentration: 17000 nM
For compound 4 the middle estimate is 1.5-fold (0.17 log units) above the measured one; the range from low to high includes it.
By their numbers in this assay, from the lowest: compounds 4, 3 and 1 (each within the scatter of the next); then compound 2.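

In this assay a fluorine-bearing group on the saturated chain carbon bound to a sulfur is now tested, and 3-(trifluoromethyl)phenyl gives no change that can be told from the methylphenyl groups: a 1.2-fold lower number from compound 3 to compound 4 (0.09 log units; within the scatter) and a 1.4-fold lower number from compound 1 to compound 4 (0.13 log units; within the scatter) both lie within the scatter. Compound 2 remains the one compound apart from the others, with a 3.4-fold lower number from compound 2 to compound 4 (0.53 log units; beyond the scatter) beyond the scatter, so among these four compounds only the naphthalen-1-yl group separates from the rest. No measurement at hand offers a reason for either result.

As far as these compounds go, what an amine, a carboxylic acid or a longer chain would do on this chain carbon remains open. So does whether trifluoromethyl elsewhere on the phenyl ring would give a number like that of compound 4.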